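Swapping the aryl group on the lactam nitrogen

The source may hold more compounds than are shown below. What is called first, only, known or untested is meant among the compounds shown, and "the series" means these compounds.

Two compounds have been measured in an in vitro functional assay on HEK293-A cells for negative allosteric modulation of metabotropic glutamate receptor 5 (Homo sapiens), read by FLIPR and calcium flux; a lower number here means a stronger inhibitor, a higher number a weaker inhibitor:

compound 1, `O=C1CC(c2nc(-c3cccc(Cl)c3)no2)CN1Cc1ccc(F)cc1` — compound 1 gives 3600 nM
compound 2, `O=C1CC(c2nc(-c3cccc(Cl)c3)no2)CN1c1ccccc1Cl` — compound 2 gives 680 nM

For the measured compounds named here, compound 2 stands at the lowest of the two numbers in this assay; its only neighbour is compound 1, separated from it by a 5.3-fold lower number from compound 1 to compound 2 (0.72 log units; beyond the scatter), a step that exceeds the scatter. That step exchanges a 4-fluorobenzyl for a 2-chlorophenyl on the amide-type nitrogen in the ring.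

Compound 3, `Cc1cccc(N2CC(c3nc(-c4cccc(Cl)c4)no3)CC2=O)c1`, keeps the shared core of compound 2 and differs in one place: 3-methylphenyl in place of 2-chlorophenyl on an amide-type nitrogen in a ring. Going by the values given here, no measured step compares two different aryl groups on that nitrogen. Among the compounds with values here, the only recorded step, a 5.3-fold lower number from compound 1 to compound 2 (0.72 log units; beyond the scatter), sets a benzyl against an aryl group and so bears on the present change only loosely; it gives no direction for replacing one aryl by another.

With that thin basis, compound 3 is expected to remain close to compound 2, and the step of a 1.3-fold higher number from compound 2 to compound 3 (0.12 log units; within the scatter) is expected to stay within or only slightly beyond the scatter. Compound 3 is therefore estimated at 900 nM, with a range from 300 nM to 3000 nM.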

Compound 3, half-maximal inhibitory concentration: 2300 nM
For compound 3 the middle estimate is 2.6-fold (0.41 log units) below the measured one; the range from low to high includes it.
By their numbers in this assay, from the lowest: compound 2; then compounds 3 and 1 (each within the scatter of the next).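

In this assay, for the compounds shown here, the step to the 3-methylphenyl, a 3.4-fold higher number from compound 2 to compound 3 (0.53 log units; beyond the scatter), gives the first comparison of two aryl groups on the amide-type nitrogen, and it shows that these two groups are not interchangeable at this position. An aryl group on this nitrogen does not by itself bring the lower number, since the step from the 4-fluorobenzyl, a 1.6-fold lower number from compound 1 to compound 3 (0.19 log units; within the scatter), stays within the scatter, and compound 3 thus goes against reading the earlier change from benzyl to aryl as a general gain. No measurement on hand accounts for the gap between the 2-chlorophenyl and the 3-methylphenyl.

This change replaces chlorine with methyl and moves the substituent on the phenyl ring at the same time, so the compounds shown leave open which of the two matters, a question that 2-methylphenyl and 3-chlorophenyl groups on the same nitrogen would separate. They also leave open how this position responds to other groups on that phenyl ring, such as a methoxy group or a nitrile, and to a pyridyl ring in place of the phenyl.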